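Hydroxy to Methoxy: The Step From Compound 2

A few compounds are considered here, and "the series" means these few. Any claim that something is new, unique, unknown or untested is made for them only; others in the source may bear on it.

Measured so far:
Compound 1 (`Cc1cc(/C=C/c2ccc(O)cc2)[nH]n1`): 45800 nM
Compound 2 (`Cc1cc(/C=C/c2ccc(O)c(O)c2)on1`): 10500 nM

In a functional assay on DU-145 cells (Homo sapiens) for cytotoxicity, read by MTT assay, with a stated time of 72 h (a higher number here means a weaker inhibitor, a lower number a stronger inhibitor), compound 2 gives 10500 nM, the lower of the two numbers and so the stronger inhibitor. Compound 1 stands at 45800 nM, a gap beyond the usual scatter. The two compounds differ in more than one place, so their values do not isolate any single change.

Compound 3 (`COc1cc(/C=C/c2cc(C)no2)ccc1O`) departs from compound 2 by methyl in place of hydrogen on an oxygen on an aromatic ring, hydroxy to methoxy. Going by the values given here, no measured pair shows this change, so the expectation is tentative. The expected step is a 1.9-fold higher number from compound 2 to compound 3 (0.28 log units; within the scatter), a small weakening in this assay, about the size of the scatter. For compound 3 the estimated value is 20000 nM, with an expected range of 7000 nM to 50000 nM.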

Compound 3, half-maximal inhibitory concentration: 28900 nM
Beside the measured number, compound 3's estimate is 1.4-fold (0.16 log units) below it; measured number inside the range.
By their numbers in this assay, from the lowest: compound 2; then compounds 3 and 1 (each within the scatter of the next).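

In this assay, going by these compounds alone, hydroxy to methoxy gives a 2.8-fold higher number from compound 2 to compound 3 (0.44 log units; beyond the scatter), the first step here that isolates a single change, since compounds 1 and 2 differ in more than one place. Methyl in place of hydrogen on this oxygen therefore weakens the compound modestly, and the free hydroxy of compound 2 goes with the lower number. Nothing available explains this step.

The compounds shown leave open whether a longer chain on this oxygen, as in ethoxy, or an amine in place of the hydroxy, would move the number further. Within the data shown here, they also leave open whether the same change on the remaining hydroxy of compound 3 would give a step of similar size, since this one pair is the only reading of the change.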